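Swapping a large ring substituent for cyanomethyl on the core

This account rests on a few compounds, and the source may have more. Where it says the series, first, only, none or still open, it means among the compounds named here.

Compound 2 `COC(=O)C(c1ccccc1)n1nnc([C@@H](COCc2ccccc2)NC(=O)C(C)(C)N)n1` gives 3170 nM in a functional assay on H4 cells for agonist activity at growth hormone secretagogue receptor type 1 (Homo sapiens), read by FLIPR (on this read-out higher numbers stand for an effect only at larger amounts of compound and lower numbers for an effect already at smaller amounts), the higher of the two numbers recorded; compound 1 `CC(C)(N)C(=O)N[C@H](COCc1ccccc1)c1nnnn1CC#N` gives 29 nM in this assay, and the gap between them is well beyond the scatter. Compound 3 `CC(C)(N)C(=O)N[C@H](COCc1ccccc1)c1nnn(CC#N)n1` differs from compound 2 by cyanomethyl in place of methoxycarbonyl)(benzyl on an aromatic nitrogen. Since compound 1 also carries cyanomethyl and gives 29 nM, a large step down is expected for a 32-fold lower number from compound 2 to compound 3 (1.50 log units; beyond the scatter). Compound 3 is therefore estimated at 100 nM, within a range of 15 nM to 800 nM.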

Compound 3, half-maximal effective concentration: 1520 nM
Compound 3: the middle estimate sits 15-fold (1.18 log units) below what was measured, and the stated range ends below it.
By their numbers in this assay, from the lowest: compound 1; then compound 3; then compound 2.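

Exchanging methoxycarbonyl)(benzyl for cyanomethyl on an aromatic nitrogen gives only a modest change in this assay, a 2.1-fold lower number from compound 2 to compound 3 (0.32 log units; beyond the scatter), so cyanomethyl alone does not produce the low number of compound 1. The attachment of the group matters far more: with 2-(cyanomethyl)-2H-tetrazol-5-yl in place of 1-(cyanomethyl)-1H-tetrazol-5-yl, the result is a 52-fold higher number from compound 1 to compound 3 (1.72 log units; beyond the scatter). Nothing available explains either step. The compounds shown leave open how a longer chain ending in a nitrile, or a carboxylic acid, would behave on this aromatic nitrogen.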